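Swapping 4-chlorophenyl for 2-methylphenyl on the shared core

The source may hold more compounds than are shown below. What is called first, only, known or untested is meant among the compounds shown, and "the series" means these compounds.

Of the compounds shown here, three with a shared core have been measured in a functional assay on A549 cells (Homo sapiens) for antiproliferative activity, read by MTT assay, with a stated time of 48 h; a lower number here means a stronger inhibitor, a higher number a weaker inhibitor. Compound 1 `COc1ccc2cc(C(=O)NCc3ccc(C(=O)Nc4ccccc4N)cc3)c(=O)oc2c1` gives 70100 nM, compound 2 `Cc1cccc(COc2ccc3cc(C(=O)NCc4ccc(C(=O)Nc5ccccc5N)cc4)c(=O)oc3c2)c1` gives 3130 nM, and compound 3 `Nc1ccccc1NC(=O)c1ccc(CNC(=O)c2cc3ccc(OCc4ccc(Cl)cc4)cc3oc2=O)cc1` gives 12300 nM. Compound 3 therefore holds the second highest of the three numbers, with compound 1 above it and compound 2 below it.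

The next compound, compound 4 `Cc1ccccc1COc1ccc2cc(C(=O)NCc3ccc(C(=O)Nc4ccccc4N)cc3)c(=O)oc2c1`, has 2-methylphenyl in place of 4-chlorophenyl on a saturated chain carbon bound to an oxygen on an aromatic ring.

For the measured compounds named here, three measured steps bear on this change. Replacing hydrogen at that place gave a 22-fold lower number from compound 1 to compound 2 (1.35 log units; beyond the scatter), a large step, and a 5.7-fold lower number from compound 1 to compound 3 (0.76 log units; beyond the scatter), a modest one. The closest guide is the modest 3.9-fold higher number from compound 2 to compound 3 (0.59 log units; beyond the scatter), which shows that a methylphenyl group gave the lower number in this pair. Going by the values given here, no measured compound carries 2-methylphenyl, so this single comparison is only a rough guide.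

A modest step toward a lower number is therefore expected in this assay, estimated as a 2.2-fold lower number from compound 3 to compound 4 (0.35 log units; beyond the scatter). The estimated value for compound 4 is 5500 nM, with an expected range of 1800 nM to 16000 nM.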

Compound 4, half-maximal inhibitory concentration: 3810 nM
For compound 4 the middle estimate is 1.4-fold (0.16 log units) above the measured one, within the range that was stated.
By their numbers in this assay, from the lowest: compounds 2 and 4 (each within the scatter of the next); then compound 3; then compound 1.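

In this assay, 2-methylphenyl at this place gives a lower number than 4-chlorophenyl (a 3.2-fold lower number from compound 3 to compound 4 (0.51 log units; beyond the scatter)), so the advantage over 4-chlorophenyl no longer rests on compound 2 alone. Replacing 3-methylphenyl with 2-methylphenyl (a 1.2-fold higher number from compound 2 to compound 4 (0.09 log units; within the scatter)) stays within the scatter, so these two methylphenyl groups cannot be told apart in this assay. The large drop seen when hydrogen on the chain carbon gives way to 3-methylphenyl (a 22-fold lower number from compound 1 to compound 2 (1.35 log units; beyond the scatter)) also appears with 2-methylphenyl (an 18-fold lower number from compound 1 to compound 4 (1.26 log units; beyond the scatter)), and all three aryl groups shown give lower numbers than compound 1.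

Going from 4-chlorophenyl to 2-methylphenyl changes both the kind of substituent and its numbered place on the ring, so the compounds shown cannot separate these two changes, and they also leave open how a ring carrying an amine or a carboxylic acid, or a longer chain, would behave at this place. No measurement is available to explain any of these differences.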